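Compound 3: Changing One Group on Compound 2

The source may hold more compounds than are shown below. What is called first, only, known or untested is meant among the compounds shown, and "the series" means these compounds.

Compound 1 `CS(=O)(=O)Nc1ccc(CNC(=O)c2ccc(C34CC(C3)C4)cc2)c(Cl)c1`: 1.35 h
Compound 2 `COC(C)(C)c1ccc(C(=O)NCc2ccc(NS(C)(=O)=O)cc2Cl)cc1`: 0.917 h

In an ADME assay on microsomes from liver (Rattus norvegicus, strain Sprague-Dawley) for metabolic stability, read by HPLC, using NADPH, with stated times of 5 min and 60 min, tested at 10 uM (on this read-out higher numbers stand for a longer-lived compound and lower numbers for a shorter-lived compound), compound 2 gives 0.917 h, and compound 1 gives 1.35 h. These two values lie within the usual scatter of each other, so neither compound stands apart.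

Compound 3 `CC(F)(F)c1ccc(C(=O)NCc2ccc(NS(C)(=O)=O)cc2Cl)cc1` alters one group of compound 2: 1,1-difluoroethyl in place of 1-methoxy-1-methylethyl on an aromatic carbon. Among the compounds with values here, no measured compound yet carries 1,1-difluoroethyl, so the data offer only indirect guidance. Within the data shown here, the one measured step that bears on this change also exchanges a group on an aromatic carbon. That step is a 1.5-fold lower number from compound 1 to compound 2 (0.17 log units; within the scatter), and it stays within the scatter. On that single precedent, no step beyond the scatter is expected in this assay. The expected change is a 1.4-fold higher number from compound 2 to compound 3 (0.15 log units; within the scatter).

Compound 3 is estimated at 1.3 h, with an expected range from 0.6 h to 2.8 h.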

Compound 3, half-life: 2.35 h
Compound 3: the middle estimate sits 1.8-fold (0.26 log units) below what was measured; the range from low to high includes it.
By their numbers in this assay, from the lowest: compounds 2, 1 and 3 (each within the scatter of the next, the first and the last beyond it).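

Within the data shown here, on this aromatic carbon, para to a large group, the choice of group can shift the reading in this assay: 1,1-difluoroethyl in place of 1-methoxy-1-methylethyl gives a 2.6-fold higher number from compound 2 to compound 3 (0.41 log units; beyond the scatter), the first step in this short series to pass beyond the scatter. The comparison with the group of two four-membered rings in compound 1 gives a 1.7-fold higher number from compound 1 to compound 3 (0.24 log units; within the scatter), so these two groups are not told apart here. Nothing available explains why the first of these steps occurs.

The compounds shown leave open where an ethyl, a trifluoromethyl or a methoxy group on this same aromatic carbon would fall relative to compound 2 and compound 3. They also leave open whether 1,1-difluoroethyl would give a similar step on a different core.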